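From 2-Acetylethyl to 3-Methoxyphenyl on the Amide Carbonyl

This account rests on a few compounds, and the source may have more. Where it says the series, first, only, none or still open, it means among the compounds named here.

Of the compounds shown here, three sharing one core have been measured in an ADME assay on L6 cells (Rattus norvegicus) for cytotoxicity; on this read-out higher numbers stand for weaker inhibition and lower numbers for stronger inhibition. Compound 1 `CC(=O)CCC(=O)NCCCN1CCN(CCCNc2ccnc3cc(Cl)ccc23)CC1` gives 11000 nM, compound 2 `CC(C)=CC(=O)NCCCN1CCN(CCCNc2ccnc3cc(Cl)ccc23)CC1` gives 30000 nM, and compound 3 `O=C(CC1CCCCC1)NCCCN1CCN(CCCNc2ccnc3cc(Cl)ccc23)CC1` gives 7200 nM. Compound 1 thus holds the second highest of the three numbers, close to compound 3 and further from compound 2. Compound 4 `COc1cccc(C(=O)NCCCN2CCN(CCCNc3ccnc4cc(Cl)ccc34)CC2)c1` differs from compound 1 in one place: 3-methoxyphenyl in place of 2-acetylethyl on a carbonyl carbon. All measured steps concern this same carbonyl position: a 2.7-fold higher number from compound 1 to compound 2 (0.44 log units; beyond the scatter), a 1.5-fold lower number from compound 1 to compound 3 (0.18 log units; within the scatter) and a 4.2-fold lower number from compound 2 to compound 3 (0.62 log units; beyond the scatter). Within the data shown here, only the step to compound 3 brings in a ring, and it stayed within the scatter, so a small move is expected, although an aromatic ring here has no direct precedent. Compound 4 is expected to give 7000 nM, between 2500 nM and 20000 nM, a step of a 1.6-fold lower number from compound 1 to compound 4 (0.20 log units; within the scatter).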

Compound 4, half-maximal inhibitory concentration: 9300 nM
Beside the measured number, compound 4's estimate is 1.3-fold (0.12 log units) below it, and the stated range covers the measured number.
By their numbers in this assay, from the lowest: compounds 3, 4 and 1 (each within the scatter of the next); then compound 2.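

An aromatic ring on this carbonyl carbon now has a measured case: in this assay 3-methoxyphenyl replaces 2-acetylethyl (a 1.2-fold lower number from compound 1 to compound 4 (0.07 log units; within the scatter)) and cyclohexylmethyl (a 1.3-fold higher number from compound 3 to compound 4 (0.11 log units; within the scatter)), so an open chain, a saturated ring and an aromatic ring all fall within the scatter here. Only the 2-methylprop-1-en-1-yl group of compound 2 stands apart, and the new compound shows that gap again (a 3.2-fold lower number from compound 2 to compound 4 (0.51 log units; beyond the scatter)). No available evidence explains these numbers. From the compounds shown here alone, whether an amine or a carboxylic acid at this position would move the number stays open, as does the part played by the methoxy group, which an unsubstituted phenyl ring would test.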